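The source may report more compounds than this note shows. Statements on the series, on what has been measured and on what is new or still open speak of the compounds shown alone.

In an ADME assay on Vero cells (Chlorocebus sabaeus) for cytotoxicity, read by fluorescence and resazurin assay, with a stated time of 3 days (a lower number here means that less compound is tolerated, a higher number that more compound is tolerated), compound 1 `CC(=O)C[C@H]1O[C@@H](On2cc(CN3C(=O)C(=O)c4ccccc43)nn2)[C@H](OC(C)=O)[C@@H](OC(C)=O)[C@@H]1OC(C)=O` gives 137000 nM, and compound 2 `CC(=O)C[C@H]1O[C@@H](On2cc(CN3C(=O)/C(=N\Nc4ccc(Br)cc4)c4ccccc43)nn2)[C@H](OC(C)=O)[C@@H](OC(C)=O)[C@@H]1OC(C)=O` gives 116000 nM. Of the two numbers, compound 2 holds the lower one, though its gap to compound 1 is within the scatter, so no order between them can be read. Compound 3 `CC(=O)C[C@H]1O[C@@H](On2cc(CN3C(=O)/C(=N\Nc4ccc(F)cc4)c4ccccc43)nn2)[C@H](OC(C)=O)[C@@H](OC(C)=O)[C@@H]1OC(C)=O` differs from compound 2 by fluoro in place of bromo on an aromatic carbon. Going by the values given here, no step between measured compounds is available for this change, and the step from compound 2 to compound 3 in this assay is expected to be a 1.0-fold higher number from compound 2 to compound 3 (0.01 log units; within the scatter), that is, nothing beyond the scatter. Compound 3 is estimated at 120000 nM, within 60000 nM to 240000 nM.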

Compound 3, half-maximal cytotoxic concentration: 68700 nM
Compound 3: middle estimate off by 1.7-fold (0.24 log units), on the high side; low and high end bracket the measured number.
By their numbers in this assay, from the lowest: compounds 3, 2 and 1 (each within the scatter of the next).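

In this assay, fluoro in place of bromo on this aromatic carbon, para to a large group, gives a 1.7-fold lower number from compound 2 to compound 3 (0.23 log units; within the scatter), which lies within the scatter, so no order between the two compounds can be read. Going by these compounds alone, this is the first step available at this position, and for these two halogens it shows no difference beyond the scatter. No measurement shown here bears on this result. From the compounds shown here alone, whether an amine, a methoxy group or a carboxylic acid on this carbon would give a step beyond the scatter remains open.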